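Lengthening the chain between carbonyl and phenyl ring

This account rests on a few compounds, and the source may have more. Where it says the series, first, only, none or still open, it means among the compounds named here.

Measured so far:
compound 1: `O=C(CCCCc1ccccc1)NNc1c(Cl)cncc1Cl` — 1200 nM
compound 2: `O=C(CCCCCc1ccccc1)NNc1c(Cl)cncc1Cl` — 1900 nM

Both compounds were tested in a functional assay on HEK293 cells for antagonist activity at P2X purinoceptor 7 (Homo sapiens), read by fluorescence, with a stated time of 2 h; on this read-out lower numbers stand for stronger inhibition and higher numbers for weaker inhibition. Compound 1 gives 1200 nM, and compound 2 gives 1900 nM. Of the two numbers, that of compound 2 is the larger, but the step of a 1.6-fold higher number from compound 1 to compound 2 (0.20 log units; within the scatter) lies within the scatter, so the two compounds cannot be told apart on these data.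

Compound 3 `O=C(CCCCCCc1ccccc1)NNc1c(Cl)cncc1Cl` continues the same series. It differs from compound 2 as follows: benzyl in place of phenyl on a saturated chain carbon, five bonds along the chain from a carbonyl carbon. Among the compounds with values here, the only measured step that bears on this change is the one from compound 1 to compound 2, a 1.6-fold higher number from compound 1 to compound 2 (0.20 log units; within the scatter), which is the same kind of lengthening made one bond closer to the carbonyl carbon. On that single step, the expectation for compound 3 in this assay is a small move toward a higher number, or none beyond the scatter. Compound 3 is therefore estimated at 2600 nM, with a range of 1200 nM to 6000 nM. This estimate means an expected step of a 1.4-fold higher number from compound 2 to compound 3 (0.14 log units; within the scatter).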

Compound 3, half-maximal inhibitory concentration: 950 nM
Compound 3: the middle estimate sits 2.7-fold (0.44 log units) above what was measured, outside the stated range (below it).
By their numbers in this assay, from the lowest: compounds 3, 1 and 2 (each within the scatter of the next).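

In this assay, the exchange of phenyl for benzyl on a saturated chain carbon, five bonds along the chain from a carbonyl carbon, gives a 2.0-fold lower number from compound 2 to compound 3 (0.30 log units; within the scatter), and the two lengthenings taken together give a 1.3-fold lower number from compound 1 to compound 3 (0.10 log units; within the scatter). Compound 3 adds a second lengthening whose printed direction is opposite to that of the first, and since neither this step nor the earlier one leaves the scatter, the three chain lengths cannot be told apart on this read-out and no trend with chain length can be claimed. Nothing available here offers an explanation for this result.

The compounds shown leave open whether a still longer chain, or a shorter one, would move the number beyond the scatter in this assay. They also leave open whether an amine or a carboxylic acid in place of phenyl would do so, or whether the number at this position stays unchanged whatever group is placed there.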